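Piperidinylmethyl for Isopropyl on the Acrylamide Chain

The compounds below may be only part of what the source reports. "The series", "measured", "known", "first", "only" and "open" are said of these compounds alone.

Measured compounds:
Compound 1, `COc1cc2ncnc(N3CCc4ccccc43)c2cc1NC(=O)/C=C/C(C)C`: 6530 nM
Compound 2, `CC(C)/C=C/C(=O)Nc1cc2c(N3CCc4ccccc43)ncnc2cc1O[C@@H]1CCOC1`: 11200 nM

Going by the values given here, in a functional assay on PC-3 cells (Homo sapiens) for antiproliferative activity, read by MTT assay, with a stated time of 72 h (a lower number here means a stronger inhibitor, a higher number a weaker inhibitor), compound 2 gives the higher of the two numbers, and the only measured step, a 1.7-fold higher number from compound 1 to compound 2 (0.23 log units; within the scatter), lies within the scatter, so compound 1 and compound 2 cannot be ordered. Compound 3, `O=C(/C=C/CN1CCCCC1)Nc1cc2c(N3CCc4ccccc43)ncnc2cc1O[C@@H]1CCOC1`, differs from compound 2 by (piperidin-1-yl)methyl in place of isopropyl on a double-bonded chain carbon bound to a double-bonded chain carbon. Among the compounds with values here, no measured step touches that part of the molecule; the single known step concerns the oxygen on the aromatic ring. With nothing to lean on, no change beyond the scatter is expected, and the expected step is a 1.2-fold lower number from compound 2 to compound 3 (0.09 log units; within the scatter). Compound 3 is therefore estimated at 9000 nM, within 2500 nM to 30000 nM.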

Compound 3, half-maximal inhibitory concentration: 4510 nM
Beside the measured number, compound 3's estimate is 2.0-fold (0.30 log units) above it, and the stated range covers the measured number.
By their numbers in this assay, from the lowest: compounds 3, 1 and 2 (each within the scatter of the next, the first and the last beyond it).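

In this assay, going by these compounds alone, the chain on the double-bonded carbon is the first place where a single change goes beyond the scatter: (piperidin-1-yl)methyl in place of isopropyl gives a 2.5-fold lower number from compound 2 to compound 3 (0.40 log units; beyond the scatter), a modest step. The position therefore accepts the larger group with its ring nitrogen, and the number falls. No available evidence explains this step. Still open, going by these compounds, is whether the ring or the nitrogen carries the step, which a dimethylamino or cyclohexyl group here would separate, and whether the change holds with methyl on the oxygen.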